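From a short-chain ester to an aryl ester at the same position

A few compounds are considered here, and "the series" means these few. Any claim that something is new, unique, unknown or untested is made for them only; others in the source may bear on it.

Compound 1 `C=C1C(=O)[C@@]23C(=O)OC[C@]4([C@@H](OC(C)=O)CCC(C)(C)[C@H]4C=O)[C@@H]2CC[C@H]1[C@H]3OC(=O)CC` and compound 2 `C=C1C(=O)[C@@]23C(=O)OC[C@]4([C@@H](OC(C)=O)CCC(C)(C)[C@H]4C=O)[C@@H]2CC[C@H]1[C@H]3OC(=O)CCCC` share one core and differ only in the acyl chain on the ester oxygen. In a functional assay on Bel-7402 cells (Homo sapiens) for inhibition, read by MTT assay (a higher number here means a weaker inhibitor, a lower number a stronger inhibitor), compound 1 gives 3780 nM, while compound 2 gives 3640 nM. The step of a 1.0-fold lower number from compound 1 to compound 2 (0.02 log units; within the scatter) shows that lengthening the chain leaves the read-out essentially unchanged, and on the two numbers available compound 1 holds the higher one, though by a margin that means nothing.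

Compound 3 `C=C1C(=O)[C@@]23C(=O)OC[C@]4([C@@H](OC(C)=O)CCC(C)(C)[C@H]4C=O)[C@@H]2CC[C@H]1[C@H]3OC(=O)c1ccc(C(F)(F)F)cc1` carries the change (4-(trifluoromethyl)phenyl in place of ethyl on a carbonyl carbon). Going by the values given here, the only measured step, from compound 1 to compound 2, involves an alkyl chain alone and says nothing about an aromatic ring bearing trifluoromethyl at this carbonyl carbon, so it bears on the new step only as a sign that this position tolerates variation without shifting the number. He therefore expects for compound 3 a step of a 1.3-fold lower number from compound 1 to compound 3 (0.10 log units; within the scatter) of modest size, with no direction that the data support, and a wide range. His estimate for compound 3 in this assay is 3000 nM, between 800 nM and 12000 nM.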

Compound 3, half-maximal inhibitory concentration: 5090 nM
Estimate against measurement, compound 3: 1.7-fold (0.23 log units) below; the measured number falls inside the stated range.
By their numbers in this assay, from the lowest: compounds 2, 1 and 3 (each within the scatter of the next).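

In this assay, the steps of a 1.3-fold higher number from compound 1 to compound 3 (0.13 log units; within the scatter) and a 1.4-fold higher number from compound 2 to compound 3 (0.15 log units; within the scatter) show that this carbonyl carbon accepts 4-(trifluoromethyl)phenyl, with its six-membered aromatic ring and 10 heavy atoms, in place of an alkyl chain, with no shift that can be told from the scatter. The earlier pair spoke only to the length of an alkyl chain, whereas the three compounds now cover both alkyl and aryl esters at this position, and their numbers in this assay do not separate them. No measurement at hand explains why this change leaves the read-out within the scatter.

The compounds shown leave open whether this tolerance extends to an acyl group carrying an amine or a carboxylic acid, or to a plain phenyl ring without trifluoromethyl. They also leave open whether a longer chain than butyl on this carbonyl carbon would behave as the shorter chains and the aryl group do.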